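Series notes: 3-carbamoylphenyl in place of 4-methylthiophen-2-yl

The source may hold more compounds than are shown below. What is called first, only, known or untested is meant among the compounds shown, and "the series" means these compounds.

Measured in an ADME assay (liver) for metabolic stability, with Liver microsome (Rattus norvegicus) as the target, using microsomes and NADPH, with a stated time of 30 min, tested at 1 uM; a higher number here means faster removal of the compound, a lower number slower removal:
- compound 1 `COc1cc(C(O)(C(F)(F)F)C(F)(F)F)cnc1N1CCN(S(=O)(=O)c2ccc(N)nc2)CC1`: < 14 mL.min-1.g-1 (a limit of the assay, not a number)
- compound 2 `Cc1csc(-c2cc(C(O)(C(F)(F)F)C(F)(F)F)cnc2N2CCN(S(=O)(=O)c3ccc(N)nc3)CC2)c1`: 399 mL.min-1.g-1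

Going by the values given here, compound 2 carries the only actual number in this set, and the other entry is a limit. Compound 3 `NC(=O)c1cccc(-c2cc(C(O)(C(F)(F)F)C(F)(F)F)cnc2N2CCN(S(=O)(=O)c3ccc(N)nc3)CC2)c1` changes one group of compound 2: 3-carbamoylphenyl in place of 4-methylthiophen-2-yl on an aromatic carbon. The new group is 3-carbamoylphenyl in place of 4-methylthiophen-2-yl on an aromatic carbon.

Among the compounds with values here, one measured step bears on this change, at the same aromatic carbon: an at least 28-fold higher number from compound 1 to compound 2 (1.45 log units; beyond the scatter). That step is large, so this assay responds strongly to the group at this place. It replaced methoxy, however, and gives no direct reading for an exchange of one aromatic ring for another, so the size of the next step remains uncertain.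

Compound 2, at 399 mL.min-1.g-1, leaves more room to fall than to rise. An aromatic ring stays at this place, so a full return to the level of compound 1 is not expected. A fall in this assay is expected, with an estimated 5.0-fold lower number from compound 2 to compound 3 (0.70 log units; beyond the scatter). For compound 3 the expected value is 80 mL.min-1.g-1, with an estimated range of 20 mL.min-1.g-1 to 300 mL.min-1.g-1.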

Compound 3, intrinsic clearance in microsomes: 63 mL.min-1.g-1
For compound 3 the middle estimate is 1.3-fold (0.10 log units) above the measured one; the measured number falls inside the stated range.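

In this assay this aromatic carbon distinguishes one aromatic ring from another, with a 6.3-fold lower number from compound 2 to compound 3 (0.80 log units; beyond the scatter), so an aromatic ring at this place does not by itself give a number as high as that of compound 2. The 3-carbamoylphenyl group also does not bring the series back to the level seen with methoxy, with an at least 4.5-fold higher number from compound 1 to compound 3 (0.65 log units; beyond the scatter). That second step gives only a minimum size, since compound 1 stands at a limit of the assay: the limit of < 14 mL.min-1.g-1 in this assay, at which 1 of the 3 values shown sits.

The exchange from compound 2 to compound 3 changes the ring size, removes the ring sulfur and methyl group, and adds the carbamoyl group all at once, so the compounds shown do not tell which of these changes carries the step. Going by these compounds, a plain phenyl ring at the same carbon, or a carboxylic acid or nitrile in place of the carbamoyl group, would help separate the contribution of the ring from that of its substituent, while the true distance between compound 1 and compound 3 remains open.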